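The source may hold more compounds than are shown below. What is called first, only, known or untested is meant among the compounds shown, and "the series" means these compounds.

The measured compounds are compound 1 `c1ccc(/N=N/N2CCCC2)cc1`, compound 2 `c1ccc(/N=N/N2CCN(c3ccccc3)CC2)cc1` and compound 3 `CCOC(=O)N1CCN(/N=N/c2ccccc2)CC1`. In an ADME assay on MDBK cells (Bos taurus) for cytotoxicity, read by MTT assay, with a stated time of 96 h (a lower number here means that less compound is tolerated, a higher number that more compound is tolerated), compound 1 gives > 100000 nM, which is a limit of the assay and not a number. Compound 2 in this assay gives > 100000 nM, again only a limit. Compound 3 in this assay gives > 100000 nM, also a limit. Compound 3 therefore stands with the other two at the limit of > 100000 nM in this assay, at which 3 of the 3 values shown sit, and no measured number separates it from compound 1 or compound 2. Going by the values given here, the one step between measured compounds that differ in one place is a step that the two limits leave unreadable from compound 2 to compound 3.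

Compound 4 `CN1CCN(/N=N/c2ccccc2)CC1` differs from compound 3 by methyl in place of ethoxycarbonyl on an amine nitrogen in a ring. Among the compounds with values here, no measured step bears on this change with a readable size, since a step that the two limits leave unreadable from compound 2 to compound 3 gives none. Because all three values shown sit at the limit of > 100000 nM in this assay, at which 3 of the 3 values shown sit, compound 4 is expected to remain at that limit as well. The step that the limit leaves unreadable from compound 3 to compound 4 is expected to be none beyond the scatter. Compound 4 is estimated in this assay at 150000 nM, with a range from 60000 nM to 400000 nM.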

Compound 4, half-maximal cytotoxic concentration: > 100000 nM
Compound 4 gave a limit, no number; the forecaster's own chance of this, stated with the estimate: 85%; the middle value does not contradict the limit.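

No step can be read from compound 2 or compound 3 to compound 4, as all three values are limits of the assay and not numbers. The compounds shown leave open whether phenyl, ethoxycarbonyl or methyl on the ring nitrogen changes tolerance in this assay at all: the limit of > 100000 nM in this assay, at which 4 of the 4 values shown sit.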